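A few compounds are considered here, and "the series" means these few. Any claim that something is new, unique, unknown or untested is made for them only; others in the source may bear on it.

Measured compounds:
- compound 1, `COc1cc(C2=NOC(CO[C@@H]3O[C@H](CSc4ncn[nH]4)[C@H]4OC5(CCCC5)O[C@@H]34)C2)cc(OC)c1OC`, gives 38000 nM in a functional assay on HeLa cells (Homo sapiens) for antiproliferative activity, read by sulforhodamine B assay, with a stated time of 48 h; on this read-out higher numbers stand for weaker inhibition of growth and lower numbers for stronger inhibition of growth
- compound 3, `COc1cc(-c2nc(CO[C@@H]3O[C@H](CSc4nnc(N)s4)[C@H]4OC5(CCCC5)O[C@@H]34)no2)cc(OC)c1OC`, gives 31000 nM in this assay
- compound 2, `Cc1ccc(S(=O)(=O)OC[C@H]2O[C@@H](OCc3noc(-c4ccc([N+](=O)[O-])cc4)n3)[C@@H]3OC4(CCCC4)O[C@@H]32)cc1`, reaches only a limit in this assay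

Compound 1 and compound 3 both carry the trimethoxyphenyl group and sit close together, within the usual scatter of each other, so neither can be called the more active. Compound 2 stands apart: for compound 2 the reading > 100000 nM is a limit of the assay, not a number, so its true potency is only known to lie on the weaker side of the two measured values (the limit of > 100000 nM in this assay, at which 1 of the 3 values shown sits).

Compound 4, `O=[N+]([O-])c1ccc(-c2nc(CO[C@@H]3O[C@H](CO)[C@H]4OC5(CCCC5)O[C@@H]34)no2)cc1`, is not yet measured. Its difference from compound 2 is counted as follows: hydrogen in place of (4-methylphenyl)sulfonyl on an oxygen on a saturated carbon. The ((4-methylphenyl)sulfonyl)oxy)methyl group of compound 2 becomes a simple hydroxymethyl in compound 4, while the nitrophenyl-bearing core is kept.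

For the measured compounds named here, no measured pair differing in one place is available, so the size of this step is unknown. Since compound 2 already sits at a limit, the step from compound 2 to compound 4 is expected to be a number no higher from compound 2 to compound 4 (the limit leaves the size open), with a fair chance that compound 4 too is reported only as a limit. The estimate for compound 4 in this assay is 100000 nM, expected to lie between 30000 nM and 300000 nM.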

Compound 4, concentration for 50% growth inhibition: 15000 nM
The estimate for compound 4 lay 6.7-fold (0.82 log units) above the measured number, and the stated range ends above it.
By their numbers in this assay, from the lowest: compound 4; then compounds 3 and 1 (each within the scatter of the next). At a limit, above all of these: compound 2.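

In this assay, putting hydrogen in place of (4-methylphenyl)sulfonyl on the oxygen turns the (((4-methylphenyl)sulfonyl)oxy)methyl group into a simple hydroxymethyl and gives an at least 6.6-fold lower number from compound 2 to compound 4 (0.82 log units; beyond the scatter). For the compounds shown here, this is the first pair in the set that differs in one place, and it shows that this position affects the read-out: with the nitrophenyl-bearing core kept, compound 4 gives 15000 nM, so the (4-methylphenyl)sulfonyl group is not needed for a measurable number here. The reading for compound 2 is a limit, so the step has a lower bound but no exact size: the limit of > 100000 nM in this assay, at which 1 of the 4 values shown sits.

Going by these compounds alone, the single pair cannot separate what the change removes, since the sulfonyl unit and its aromatic ring leave together while a free hydroxy group appears, so a methyl ether, an acetate or an amine on the same carbon would be needed to tell these apart. On these data alone, whether the same swap lowers the number on another core, such as that of compound 1 with its trimethoxyphenyl group, also remains open.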